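From Methoxy to Hydrogen at a Half-Life Limit

This account rests on a few compounds, and the source may have more. Where it says the series, first, only, none or still open, it means among the compounds named here.

Measured so far in a physicochemical assay for pharmacokinetics; a higher number here means that the compound lasts longer, a lower number that the compound disappears faster:
Compound 1 `O=C(NCc1cccc2ccccc12)N1C(=O)c2ccccc2S1(=O)=O`: > 166 h
Compound 2 `COc1cccc(CNC(=O)N2C(=O)c3ccccc3S2(=O)=O)c1`: > 166 h
Compound 3 `O=C(c1ccccc1)N1C(=O)c2ccccc2S1(=O)=O`: > 0.875 h

None of these three results is a number; each is a limit of the assay. In this assay compound 2 stands at > 166 h, which is a limit. Its exact half-life is therefore unknown, and the comparison that follows starts from an open-ended value.

Compound 4 `O=C(NCc1ccccc1)N1C(=O)c2ccccc2S1(=O)=O` has not yet been measured. It differs from compound 2 by hydrogen in place of methoxy on an aromatic carbon, meta to a large group (hydrogen in place of methoxy on an aromatic carbon). The same difference can be read as 3-methoxyphenyl to phenyl.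

Among the measured compounds shown here, no pair of measured compounds differs in one place only, so the data give no direct size for such a change. The expectation rests mainly on compound 1, which gives > 166 h, also a limit. On that basis, no change beyond the usual scatter is expected in this assay, and neither direction is favoured. The expected size is a step that the limit leaves unreadable from compound 2 to compound 4, and a further limit rather than a number would be no surprise. For compound 4 the estimated half-life is 170 h, with an expected range of 70 h to 400 h.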

Compound 4, half-life: > 166 h
Compound 4: no number, only a limit (the forecaster's own chance of this, stated with the estimate: 65%); the middle value is on the limit's open side.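

In this assay compound 4 gives > 166 h which is a limit and not a number. Among the compounds shown here, compound 2 also stands at a limit, and no step between compound 2 and compound 4 can be read. The compounds shown leave open the actual half-lives of both compounds and whether hydrogen in place of methoxy changes the half-life at all.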